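Replacing the Whole Side Chain of Compound 2

The compounds below may be only part of what the source reports. "The series", "measured", "known", "first", "only" and "open" are said of these compounds alone.

In a functional assay on MCF7 cells (Homo sapiens) for antiproliferative activity, read by CCK-8 assay, with a stated time of 48 h (on this read-out higher numbers stand for weaker inhibition and lower numbers for stronger inhibition), compound 1 `CNC(=O)/C=C/CNCCOc1ccc(Oc2c(-c3ccc(F)cc3)sc3cc(O)ccc23)cc1` gives 16100 nM and compound 2 `O=C(/C=C/CNCCOc1ccc(Oc2c(-c3ccc(F)cc3)sc3cc(O)ccc23)cc1)N1CCC1` gives 7340 nM, the lower of the two numbers. For the measured compounds named here, the only measured step, a 2.2-fold lower number from compound 1 to compound 2 (0.34 log units; beyond the scatter), is modest but beyond the scatter, and it comes from azetidin-1-yl replacing methylamino on a carbonyl carbon. Compound 3 `C=CC(=O)N1CC(Oc2ccc(Oc3c(-c4ccc(F)cc4)sc4cc(O)ccc34)cc2)C1` differs from compound 2 far more widely: 1-(vinylcarbonyl)azetidin-3-yl in place of 2-((3-((azetidin-1-yl)carbonyl)prop-2-en-1-yl)amino)ethyl on an oxygen on an aromatic ring. Neither measured compound carries the 1-(vinylcarbonyl)azetidin-3-yl group, so a 2.2-fold lower number from compound 1 to compound 2 (0.34 log units; beyond the scatter) offers a sense of scale but no direction for this exchange. No shift beyond the scatter is therefore expected as the best guess, though with wide uncertainty in either direction. The expected change is a 1.2-fold lower number from compound 2 to compound 3 (0.09 log units; within the scatter), and this estimate is tentative. For compound 3 the estimated value is 6000 nM, with an expected range of 1500 nM to 24000 nM.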

Compound 3, half-maximal inhibitory concentration: 23500 nM
Compound 3: the middle estimate sits 3.9-fold (0.59 log units) below what was measured; measured number inside the range.
By their numbers in this assay, from the lowest: compound 2; then compounds 1 and 3 (each within the scatter of the next).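

The oxygen on the aromatic ring is a place where changing the whole side chain registers: with 1-(vinylcarbonyl)azetidin-3-yl entering, this assay shows a 3.2-fold higher number from compound 2 to compound 3 (0.51 log units; beyond the scatter), so the new group does not hold the level of the azetidin-1-yl amide chain. Against the methylamino amide chain, the same group gives a 1.5-fold higher number from compound 1 to compound 3 (0.16 log units; within the scatter), which lies within the scatter, so compound 3 and compound 1 cannot be told apart. Nothing measured here explains either step.

As far as these compounds go, the two chains differ in several parts at once, so it remains open which part carries the step from the azetidin-1-yl amide chain. Also open, from the compounds shown here alone, is how a simple 2-(dimethylamino)ethyl group or a 1-(vinylcarbonyl)pyrrolidin-3-yl group on that oxygen would read.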